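Adding a Fluorine to the Ethylamide Analogue

The source may report more compounds than this note shows. Statements on the series, on what has been measured and on what is new or still open speak of the compounds shown alone.

Of the compounds shown here, three built on one shared core have been measured. Compound 1 `CNC(=O)c1cc(Oc2ccc(NC(=O)c3cc4cccnc4n(-c4ccccc4)c3=O)cc2)ccn1` gives 1820 nM in a functional assay on U-87MG ATCC cells for antiproliferative activity against U-87 MG (Homo sapiens), read by MTT assay, with a stated time of 72 h; a higher number here means a weaker inhibitor, a lower number a stronger inhibitor. Compound 2 `CNC(=O)c1cc(Oc2ccc(NC(=O)c3cc4cccnc4n(-c4ccccc4F)c3=O)cc2)ccn1` gives 3360 nM in this assay, and compound 3 `CCNC(=O)c1cc(Oc2ccc(NC(=O)c3cc4cccnc4n(-c4ccccc4)c3=O)cc2)ccn1` gives 2650 nM. On these numbers compound 3 stands second highest of the three, but both its neighbours lie within the usual scatter of it, so no reliable order among the three can be read.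

Compound 4 `CCNC(=O)c1cc(Oc2ccc(NC(=O)c3cc4cccnc4n(-c4ccccc4F)c3=O)cc2)ccn1` has not yet been measured. It differs from compound 3 in a single way: fluoro in place of hydrogen on an aromatic carbon. The same change has been made once already, on the methylamide pair, where a 1.8-fold higher number from compound 1 to compound 2 (0.27 log units; within the scatter). The other measured step, a 1.5-fold higher number from compound 1 to compound 3 (0.16 log units; within the scatter), is the change that separates compound 3 from compound 1 and says nothing directly about the fluorine. For the measured compounds named here, the one step that bears on the question therefore points to a somewhat higher number, still inside the scatter, and no step beyond the scatter is expected from compound 3 to compound 4. The expected step is a 1.5-fold higher number from compound 3 to compound 4 (0.18 log units; within the scatter). Compound 4 is accordingly estimated at 4000 nM, with a range from 2000 nM to 9000 nM.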

Compound 4, half-maximal inhibitory concentration: 3250 nM
Compound 4: the middle estimate sits 1.2-fold (0.09 log units) above what was measured; the measured number falls inside the stated range.
By their numbers in this assay, from the lowest: compounds 1, 3, 4 and 2 (each within the scatter of the next).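

Moving from phenyl to 2-fluorophenyl now has a second reading in this assay: on the ethylamide it gives a 1.2-fold higher number from compound 3 to compound 4 (0.09 log units; within the scatter), and the two readings of this change agree within the scatter: the same change on two cores in this assay, a 1.8-fold higher number (0.27 log units; within the scatter) from compound 1 to compound 2 and a 1.2-fold higher number (0.09 log units; within the scatter) from compound 3 to compound 4, 1.5-fold (0.18 log units) apart, within the scatter of two such steps. Compound 4 also completes a square of four compounds, so lengthening the methylamide to the ethylamide can be read a second time, now with the fluoro present, as a 1.0-fold lower number from compound 2 to compound 4 (0.01 log units; within the scatter), and this reading also agrees with the first: the same change on two cores in this assay, a 1.5-fold higher number (0.16 log units; within the scatter) from compound 1 to compound 3 and a 1.0-fold lower number (0.01 log units; within the scatter) from compound 2 to compound 4, 1.5-fold (0.18 log units) apart, within the scatter of two such steps. Across these four compounds, neither change, alone or combined with the other, gives a step beyond the scatter, and neither appears to alter what the other does.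

The compounds shown carry only hydrogen or fluoro at this ring position and only a methyl or ethyl group on the amide nitrogen. On these data alone, it remains open whether a larger replacement, such as a chloro or methoxy group or an amine on the ring, or a longer chain such as propyl or butyl on the amide, would produce a step beyond the scatter.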